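The source may hold more compounds than are shown below. What is called first, only, known or untested is meant among the compounds shown, and "the series" means these compounds.

Measured so far:
- compound 1, `CSc1ccccc1N1C(N)=NC(N)=NC1(C)C`, 2.48
- compound 2, `CC1(C)N=C(N)N=C(N)N1c1ccccc1S`, 6.86

Both compounds were tested in an assay on isolated protein for inhibition of Dihydrofolate reductase (Mus musculus), at pH 7.20; on this read-out higher numbers stand for higher potency (the scale is a negative logarithm) and lower numbers for lower potency. Among the measured compounds shown here, compound 1 stands lowest of the two numbers; its nearest neighbour is compound 2, and the one measured step, a number 4.38 log units higher from compound 1 to compound 2 (beyond the scatter), is well beyond the scatter.

Compound 3, `CC1(C)N=C(N)N=C(N)N1c1ccccc1I`, has not yet been measured. It differs from compound 1 in one place: iodo in place of methylsulfanyl on an aromatic carbon. For the measured compounds named here, no measured step replaces the methylsulfanyl group with a halogen, so nothing here speaks to this change directly. Going by the values given here, the only step in hand, a number 4.38 log units higher from compound 1 to compound 2 (beyond the scatter), concerns a different change on the same sulfur and shows that the number at this position can move far. It does not say in which direction an iodo group would move it.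

For compound 3 a step of a number 1.02 log units higher from compound 1 to compound 3 (beyond the scatter) is expected, with wide uncertainty. Compound 3 is therefore estimated at 3.5, between 2.3 and 5.5.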

Compound 3, logarithm of the reciprocal of the active concentration, log(1/C): 2.49
Estimate against measurement, compound 3: 1.01 log units above; low and high end bracket the measured number.
By their numbers in this assay, from the lowest: compounds 1 and 3 (each within the scatter of the next); then compound 2.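

Replacing methylsulfanyl with iodo leaves the number in this assay unchanged within the scatter (a number 0.01 log units higher from compound 1 to compound 3 (within the scatter)), so these two different groups cannot be told apart on this read-out. The second new step (a number 4.37 log units lower from compound 2 to compound 3 (beyond the scatter)) shows that compound 2 stands alone among the three, far above both compounds that carry something else at this position. Sulfur alone therefore does not go with the high number, as compound 1 also carries sulfur yet matches compound 3, which has none; so far, the high number is seen only with the sulfanyl group.

On these data alone, whether an amine, a hydroxyl or a smaller halogen such as chlorine would come close to compound 2 or stay with compound 1 and compound 3 remains open. Nothing available explains why the sulfanyl compound stands apart from the other two.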